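From fluorophenyl to pyridyl carbamoyl: what compound 4 may tolerate

The source may report more compounds than this note shows. Statements on the series, on what has been measured and on what is new or still open speak of the compounds shown alone.

Of the compounds shown here, three built on one shared core have been measured in an ADME assay on MT4 cells (Homo sapiens) for cytotoxicity, read by MTT assay; a higher number here means that more compound is tolerated, a lower number that less compound is tolerated. Compound 1 `Cc1cc(C)cc(S(=O)(=O)c2c(C(=O)NC(C)C(=O)NCCn3c(C)cnc3[N+](=O)[O-])[nH]c3ccc(Cl)cc23)c1` gives 16000 nM. Compound 2 `Cc1cc(C)cc(S(=O)(=O)c2c(C(=O)NC(C)c3ccco3)[nH]c3ccc(Cl)cc23)c1` reaches only the limit > 54700 nM, a bound of this assay rather than a number. Compound 3 `Cc1cc(C)cc(S(=O)(=O)c2c(C(=O)NC(C)c3ccccc3F)[nH]c3ccc(Cl)cc23)c1` likewise stops at the limit > 51500 nM, which is the limit of > 51500 nM in this assay, at which 1 of the 3 values shown sits. For the measured compounds named here, the single step between measured neighbours, a step that the two limits leave unreadable from compound 2 to compound 3, therefore cannot be sized. Compound 4 `Cc1cc(C)cc(S(=O)(=O)c2c(C(=O)NC(C)C(=O)NC(C)c3ccncc3)[nH]c3ccc(Cl)cc23)c1` differs from compound 3 by (1-(pyridin-4-yl)ethyl)carbamoyl in place of 2-fluorophenyl on a saturated chain carbon bound to an amide-type nitrogen and a saturated chain carbon. Going by the values given here, no measured step spans such a change. Compound 1, which also carries an extended amide chain, returns a real number at 16000 nM. Among the compounds with values here, compounds 2 and 3, with compact aryl groups, return no number in this assay; with no step recorded between compound 1 and compound 3, this is only what the values show. Compound 4 is expected near 30000 nM, between 10000 nM and 60000 nM, with a fair chance that this assay again reports only a limit. The step of an at least 1.7-fold lower number from compound 3 to compound 4 (0.23 log units; that floor lies within the scatter) is expected to be uncertain in direction.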

Compound 4, half-maximal cytotoxic concentration: 21900 nM
Beside the measured number, compound 4's estimate is 1.4-fold (0.14 log units) above it; measured number inside the range.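

In this assay, for the compounds shown here, (1-(pyridin-4-yl)ethyl)carbamoyl on a saturated chain carbon bound to an amide-type nitrogen and a saturated chain carbon gives the first readable steps at this position: an at least 2.3-fold lower number from compound 3 to compound 4 (0.37 log units; beyond the scatter), and with furan-2-yl as the group replaced, an at least 2.4-fold lower number from compound 2 to compound 4 (0.39 log units; beyond the scatter). Compound 3 stands only at a limit, so the first of these steps is a floor and not a size: the limit of > 51500 nM in this assay, at which 1 of the 4 values shown sits. The change in the group on the amide-type nitrogen shows a 1.4-fold higher number from compound 1 to compound 4 (0.14 log units; within the scatter), so compound 1 and compound 4 cannot be told apart in this assay.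

Compound 4 brings in the carbamoyl and the pyridin-4-yl ring in a single change, and the compounds shown do not separate the two. Going by these compounds, how a phenyl ring or a carboxylic acid in place of the pyridin-4-yl ring would read in this assay stays open.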